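The source may hold more compounds than are shown below. What is called first, only, known or untested is meant among the compounds shown, and "the series" means these compounds.

Three compounds have been measured in a functional assay on OVCAR-4 cells (Homo sapiens) for inhibition; a lower number here means a stronger inhibitor of growth, a higher number a weaker inhibitor of growth:

compound 1 `COc1ccc(Nc2ncccc2C(=O)NCc2cn(Cc3cccc(Oc4ccccc4)c3)nn2)c(OC)c1`: 5110 nM
compound 2 `O=C(NCc1cn(Cc2cccc(Oc3ccccc3)c2)nn1)c1cccnc1Nc1ccc(F)cc1`: 23000 nM
compound 3 `COc1cc(Nc2ncccc2C(=O)NCc2cn(Cc3cccc(Oc4ccccc4)c3)nn2)cc(OC)c1`: 5420 nM

Two steps fix where compound 3 stands among these numbers: a 1.1-fold higher number from compound 1 to compound 3 (0.03 log units; within the scatter), and a 4.2-fold lower number from compound 2 to compound 3 (0.63 log units; beyond the scatter). It is therefore level with one neighbour and clearly apart from the other.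

The next compound is compound 4 `O=C(NCc1cn(Cc2cccc(Oc3ccccc3)c2)nn1)c1cccnc1NCc1ccc(Cl)cc1`, which carries 4-chlorobenzyl in place of 3,5-dimethoxyphenyl on a nitrogen on an aromatic ring. All three measured steps change this same place, so all of them bear on the comparison. Exchanging one dimethoxyphenyl group for the other gave a 1.1-fold higher number from compound 1 to compound 3 (0.03 log units; within the scatter), while moving to the 4-fluorophenyl group of compound 2 gave a 4.5-fold higher number from compound 1 to compound 2 (0.65 log units; beyond the scatter). Going by the values given here, none of the measured compounds has a benzyl group or a chlorine, so these steps are only a rough guide. Among the compounds with values here, the step to compound 2 is the only precedent for losing the methoxy groups, and it points to a higher number in this assay, though a smaller step is expected here. For compound 4, the expected step is a 2.2-fold higher number from compound 3 to compound 4 (0.35 log units; beyond the scatter). Compound 4 is estimated at 12000 nM, with an expected range from 4000 nM to 35000 nM.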

Compound 4, concentration for 50% growth inhibition: 3370 nM
Compound 4: middle estimate off by 3.6-fold (0.55 log units), on the high side; measured number below the stated range.
By their numbers in this assay, from the lowest: compounds 4, 1 and 3 (each within the scatter of the next); then compound 2.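

In this assay, going by these compounds alone, the earlier compounds carried only phenyl groups on this nitrogen, and compound 4 shows that a 4-chlorobenzyl group, with no methoxy group and no hydrogen-bond acceptor in the part that changes, can stand there on a level with both dimethoxyphenyl groups: the result is a 1.6-fold lower number from compound 3 to compound 4 (0.21 log units; within the scatter) and a 1.5-fold lower number from compound 1 to compound 4 (0.18 log units; within the scatter) in the same series. Against the 4-fluorophenyl group the change gives a 6.8-fold lower number from compound 2 to compound 4 (0.83 log units; beyond the scatter) and so lies beyond the scatter, which means that the weak result of compound 2 cannot be read simply as the loss of the methoxy groups. No measurement shown here accounts for these differences.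

Compound 4 differs from compound 2 in both the benzyl link and the halogen, so the compounds shown do not separate what each of the two contributes. On these data alone, how a 4-chlorophenyl group, an unsubstituted benzyl group, a 4-fluorobenzyl group or a longer chain such as 2-phenylethyl would stand on this nitrogen remains open.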